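A few compounds are considered here, and "the series" means these few. Any claim that something is new, unique, unknown or untested is made for them only; others in the source may bear on it.

Within the data shown here, compound 2 `CCOc1ccc2sc(S(C)(=O)=O)nc2c1S(=O)(=O)Nc1ccc(Br)cc1` gives 40700 nM in a functional assay on HeLa cells (Homo sapiens) for inhibition, read by sulforhodamine B assay, with a stated time of 48 h (a higher number here means a weaker inhibitor of growth, a lower number a stronger inhibitor of growth), the higher of the two numbers measured, with compound 1 `CCOc1ccc2sc(S(C)(=O)=O)nc2c1S(=O)(=O)NC(C)(C)C` as its only neighbour at 38600 nM. Among the measured compounds shown here, the step of a 1.1-fold higher number from compound 1 to compound 2 (0.02 log units; within the scatter) is the one measured change at the sulfonamide nitrogen, and it stayed within the scatter. Compound 3 `CCOc1ccc2sc(S(C)(=O)=O)nc2c1S(=O)(=O)NC(CC)CC` has not been measured; it differs from compound 2 by pentan-3-yl in place of 4-bromophenyl on a sulfonamide nitrogen. For the measured compounds named here, because the single step of a 1.1-fold higher number from compound 1 to compound 2 (0.02 log units; within the scatter) at this same nitrogen, an exchange of one branched alkyl group for an aromatic one, produced no change beyond the scatter, the return to a branched alkyl group, pentan-3-yl, is expected to leave the number in this assay essentially where it is. The expected step of a 1.0-fold lower number from compound 2 to compound 3 (0.02 log units; within the scatter) is therefore one with no direction beyond the scatter. Compound 3 is estimated at 39000 nM, with a likely range from 14000 nM to 110000 nM.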

Compound 3, concentration for total growth inhibition: 53500 nM
Beside the measured number, compound 3's estimate is 1.4-fold (0.14 log units) below it; measured number inside the range.
By their numbers in this assay, from the lowest: compounds 1, 2 and 3 (each within the scatter of the next).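

The step of a 1.3-fold higher number from compound 2 to compound 3 (0.12 log units; within the scatter) and the step of a 1.4-fold higher number from compound 1 to compound 3 (0.14 log units; within the scatter) both lie within the scatter in this assay, so pentan-3-yl on the sulfonamide nitrogen cannot be told apart from either 4-bromophenyl or tert-butyl. This adds a direct comparison of two branched alkyl groups, which the earlier pair did not offer, and across these three compounds no exchange at this nitrogen goes beyond the scatter. No supporting evidence bears on this result.

The compounds leave open whether a chain ending in an amine or a carboxylic acid on this nitrogen would move the number beyond the scatter. From the compounds shown here alone, the ethoxy and methylsulfonyl groups are the same in all three compounds, so their part in the number remains open too.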